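A few compounds are considered here, and "the series" means these few. Any claim that something is new, unique, unknown or untested is made for them only; others in the source may bear on it.

The compounds in this series share the core of compound 1 `C=C(CCCC(C)C)c1ccc(CO)cc1O`, a phenol carrying a hydroxymethyl group and an unsaturated side chain. In a functional assay on cells (Neutrophil, Homo sapiens) for inhibition, read by spectrophotometry, with a stated time of 5 min (on this read-out lower numbers stand for stronger inhibition and higher numbers for weaker inhibition), compound 1 has "not determined" (no result reported). Compound 2 `CC(C)CCC[C@](C)(O)c1ccc(C(=O)O)cc1O` gives in this assay a value of 27800 nM. Compound 3 `C/C(=C\CCC(C)CO)c1ccc(CO)cc1O` gives in this assay a value of 21500 nM. Of the two numbers available, compound 3 has the lower one, yet its gap to compound 2 lies within the scatter, so the two cannot be put in order on this evidence. Among the measured compounds shown here, no pair of measured compounds differs in a single place, so no measured step exists to lean on.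

Compound 4 `C/C(=C\CCC(C)C)c1ccc(CO)cc1O` differs from compound 3 in one respect: hydrogen in place of hydroxy on a saturated chain carbon, four bonds along the chain from a double-bonded chain carbon. Nothing in the measured set shows what this change does, so the step is expected to be small. Compound 4 is expected to give about 20000 nM, with a range from 6000 nM to 65000 nM. The implied step a 1.1-fold lower number from compound 3 to compound 4 (0.03 log units; within the scatter) is expected to stay within the scatter, in no clear direction.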

Compound 4, half-maximal inhibitory concentration: 6110 nM
Compound 4: middle estimate off by 3.3-fold (0.51 log units), on the high side, and the stated range covers the measured number.
By their numbers in this assay, from the lowest: compound 4; then compounds 3 and 2 (each within the scatter of the next).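

In this assay the exchange of hydroxy for hydrogen on a saturated chain carbon, four bonds along the chain from a double-bonded chain carbon, brings a 3.5-fold lower number from compound 3 to compound 4 (0.55 log units; beyond the scatter) and so gives the series its first measured step. It shows that this position of the side chain is not indifferent to the change, and that the hydroxymethyl is not needed for inhibition here, since the methyl-bearing compound 4 has the lower number. The step is modest and rests on this single pair, and nothing at hand accounts for it.

On these data alone, whether an amine, a methoxy group or a fluorine at this carbon would move the number in the same direction remains open. So does the effect of a longer chain in place of the isopropyl end.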